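Uracil alkyl phosphates: extending the phosphate to a triphosphate

A few compounds are considered here, and "the series" means these few. Any claim that something is new, unique, unknown or untested is made for them only; others in the source may bear on it.

Measured compounds:
compound 1, `O=c1ccn(CCCCOP(=O)(O)O)c(=O)[nH]1`: <= 500000 nM
compound 2, `O=c1ccn(CCCCCOP(=O)(O)O)c(=O)[nH]1`: 267000 nM

Compound 1 `O=c1ccn(CCCCOP(=O)(O)O)c(=O)[nH]1` in a functional assay on NG108-15 cells for antagonist activity at P2Y purinoceptor 2 (Mus musculus), read by fluorescence and calcium flux, with a stated time of 30 min (a higher number here means a weaker inhibitor, a lower number a stronger inhibitor), gives only a limit, <= 500000 nM. Among the measured compounds shown here, compound 2 `O=c1ccn(CCCCCOP(=O)(O)O)c(=O)[nH]1` gives 267000 nM in this assay, the sole numbered value in the pair. The step that the limit leaves unreadable from compound 1 to compound 2 cannot be sized, since one end rests at the limit of <= 500000 nM in this assay, at which 1 of the 2 values shown sits.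

Compound 3 `O=c1ccn(CCCCCOP(=O)(O)OP(=O)(O)OP(=O)(O)O)c(=O)[nH]1` differs from compound 2 by a group of 8 heavy atoms (6 oxygen, 2 phosphorus; no ring) in place of a hydrogen atom, on an oxygen. No measured step bears on this change; the single step shown is unreadable. Compound 3 is therefore estimated at 150000 nM, with a range from 30000 nM to 500000 nM. The expected step of a 1.8-fold lower number from compound 2 to compound 3 (0.25 log units; within the scatter) is not taken to exceed the scatter.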

Compound 3, half-maximal inhibitory concentration: 500000 nM
For compound 3 the middle estimate is 3.3-fold (0.52 log units) below the measured one, within the range that was stated.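

In this assay, among the compounds shown here, a group of 8 heavy atoms in place of the hydrogen on the oxygen, extending the phosphate to a triphosphate, gives a 1.9-fold higher number from compound 2 to compound 3 (0.27 log units; within the scatter) and is the first readable step. The phosphate and the triphosphate are therefore not separated at this position in this assay. The only other reference point is a limit, that of compound 1: the limit of <= 500000 nM in this assay, at which 1 of the 3 values shown sits.

As far as these compounds go, the step from compound 1 to compound 2 cannot be read, so the effect of chain length remains open. Also open, from the compounds shown here alone, is what a longer chain, or a carboxylic acid in place of the phosphate, would give.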